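This account rests on a few compounds, and the source may have more. Where it says the series, first, only, none or still open, it means among the compounds named here.

Working notes on the arylalkyne propanoic acid series.

Three compounds carry numbers in an in vitro functional assay on 1321-N1 cells for agonist activity at Free fatty acid receptor 1 (Homo sapiens), read by fluorescence, spectrophotometry and calcium flux; a higher number here means that more compound is needed for the effect, a lower number that less compound is needed. Compound 1 `Cc1ccccc1-c1cc(C#Cc2ccc(CCC(=O)O)cc2)ccn1` gives 1070 nM and sits second highest of the three. Compound 2 `Cc1cc(C#Cc2ccc(CCC(=O)O)cc2)nc(Cl)n1` gives 2750 nM, a step up from compound 1 that lies beyond the scatter, while compound 3 `O=C(O)CCc1ccc(C#Cc2cccs2)cc1` gives 251 nM, a step down from compound 1 that also lies beyond the scatter. So compound 1 stands between the two, closer to compound 2 than to compound 3.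

Compound 4 `O=C(O)CCc1ccc(C#Cc2ccnc(F)c2)cc1` is not yet measured. Relative to compound 1 the change is fluoro in place of 2-methylphenyl on an aromatic carbon. Among the measured compounds shown here, no measured pair makes this exact step, so its size is a guess. Within the three numbers, the smallest aryl group on compound 3 gives the lowest value and the substituted diazine on compound 2 gives the highest, with compound 1 between; compound 4 carries a small halogenated six-membered azine, which reads as intermediate between those cases. The step from compound 1 to compound 4 in this assay is expected to be a 1.5-fold lower number from compound 1 to compound 4 (0.18 log units; within the scatter), a modest drop that may not clear the scatter. Compound 4 is estimated at 700 nM, with a range from 200 nM to 2500 nM.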

Compound 4, half-maximal effective concentration: 513 nM
For compound 4 the middle estimate is 1.4-fold (0.13 log units) above the measured one; measured number inside the range.
By their numbers in this assay, from the lowest: compound 3; then compound 4; then compound 1; then compound 2.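

In this assay, replacing 2-methylphenyl with fluoro on an aromatic carbon next to the ring nitrogen gives a 2.1-fold lower number from compound 1 to compound 4 (0.32 log units; beyond the scatter). At this place, then, the aromatic ring of carbon only and its methyl group can be given up entirely without the number rising, and the modest step runs toward less compound being needed. Nothing measured in the series gives a reason for this step.

Going by these compounds, it remains open whether the lower number follows from the fluoro group itself or simply from the loss of 2-methylphenyl, a question that a chloro, methoxy or amino group on the same carbon would address. An unsubstituted phenyl group there would show whether the methyl group or the whole ring accounts for the higher number of compound 1.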